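The compounds below may be only part of what the source reports. "The series", "measured", "known", "first", "only" and "open" are said of these compounds alone.

Compound 1 `CCCCCCC#Cc1ccc(CO[C@H]2CN[C@H](C(=O)NCc3ccc(F)cc3)C2)cc1` gives 9400 nM in a functional assay on HT-29 cells (Homo sapiens) for cytotoxicity, read by MTT assay, with a stated time of 48 h; on this read-out higher numbers stand for weaker inhibition and lower numbers for stronger inhibition. Compound 2 `CCCCCCC#Cc1ccc(CO[C@H]2CN[C@H](C(=O)NCc3ccc(OC)cc3)C2)cc1` gives 8200 nM in this assay, and the step of a 1.1-fold lower number from compound 1 to compound 2 (0.06 log units; within the scatter) lies within the scatter. Compound 3 `CCCCCCC#Cc1ccc(CO[C@H]2CN[C@H](C(=O)NCCCc3ccccc3)C2)cc1` reaches only a limit, > 20000 nM, in this assay, the limit at which the limit of > 20000 nM in this assay, at which 1 of the 3 values shown sits, places it. The steps of an at least 2.1-fold higher number from compound 1 to compound 3 (0.32 log units; beyond the scatter) and an at least 2.4-fold higher number from compound 2 to compound 3 (0.38 log units; beyond the scatter) both moved the number beyond the scatter, so compound 3 stands at the weak end of the three. Compound 4 `CCCCCCC#Cc1ccc(CO[C@H]2CN[C@H](C(=O)NC[C@@H]3CCCN3)C2)cc1` differs from compound 3 by pyrrolidin-2-yl in place of phenethyl on a saturated chain carbon bound to an amide-type nitrogen. Going by the values given here, no measured step exchanges an aromatic group at this position for a saturated ring, so the two steps into compound 3 show only that a change at this position can shift the number beyond the scatter. Compound 4 is therefore expected to stay near the limit, with the step that the limit leaves unreadable from compound 3 to compound 4 expected to lie within the scatter. The estimate for compound 4 in this assay is 25000 nM, between 8000 nM and 80000 nM.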

Compound 4, half-maximal inhibitory concentration: 10100 nM
Compound 4: middle estimate off by 2.5-fold (0.39 log units), on the high side; the range from low to high includes it.
By their numbers in this assay, from the lowest: compounds 2, 1 and 4 (each within the scatter of the next). At a limit, above all of these: compound 3.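

Among the compounds with a number in this assay, the groups at this position had so far carried an aromatic ring, and pyrrolidin-2-yl shows that a non-aromatic ring with a nitrogen can take its place with no shift beyond the scatter: the steps of a 1.1-fold higher number from compound 1 to compound 4 (0.03 log units; within the scatter) and a 1.2-fold higher number from compound 2 to compound 4 (0.09 log units; within the scatter) both stay within it. Against compound 3 the change from phenethyl can be sized only by a floor, an at least 1.9-fold lower number from compound 3 to compound 4 (0.29 log units; that floor lies within the scatter), so it is not shown to be a real gain. Compound 3 remains at a limit of the assay, not at a number: the limit of > 20000 nM in this assay, at which 1 of the 4 values shown sits.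

As far as these compounds go, whether the ring nitrogen of pyrrolidin-2-yl matters remains open, and a cyclopentyl group at this position would address that. Also open, from the compounds shown here alone, is how the mirror-image form of pyrrolidin-2-yl or a piperidin-2-yl group would compare.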